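Tetrazole analogue of an ester series sitting at the limit

The source may hold more compounds than are shown below. What is called first, only, known or untested is meant among the compounds shown, and "the series" means these compounds.

Measured compounds, all in an assay on HEK293 cells for inhibition of Ataxin-2 (Mus musculus), read by fluorescence and Amplex Red; a lower number here means a stronger inhibitor, a higher number a weaker inhibitor:
- compound 1 `COC(=O)c1ccc(COc2ccc(CNC(=O)[C@@H]3CCC(=O)N3Cc3ccccc3)cc2)cc1` gives > 5000 nM, a limit of the assay.
- compound 2 `O=C(O)c1ccc(COc2ccc(CNC(=O)[C@@H]3CCC(=O)N3Cc3ccc(F)cc3)cc2)cc1` gives > 5000 nM, a limit of the assay.
- compound 3 `O=C1CC[C@@H](C(=O)NCc2ccc(OCc3ccc(C(=O)O)cc3)cc2)N1` gives > 5000 nM, a limit of the assay.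

Compound 1 thus stands only at a limit in this assay; no number is known for it. For the measured compounds named here, the single one-place step among the measured compounds, a step that the two limits leave unreadable from compound 2 to compound 3, cannot be read, because the limit of > 5000 nM in this assay, at which 3 of the 3 values shown sit, holds both of its ends.

Compound 4 `O=C(NCc1ccc(OCc2ccc(-c3nn[nH]n3)cc2)cc1)[C@@H]1CCC(=O)N1Cc1ccccc1` differs from compound 1 by 2H-tetrazol-5-yl in place of methoxycarbonyl on an aromatic carbon. Going by the values given here, no measured step touches this change, and the one step that exists is unreadable, so no direction can be drawn from the measured pairs. Since all values sit at the limit shown by the limit of > 5000 nM in this assay, at which 3 of the 3 values shown sit, compound 4 is expected to remain at or near that limit as well. The step that the limit leaves unreadable from compound 1 to compound 4 from compound 1 to compound 4 is estimated to stay within the scatter. Compound 4 is estimated at 10000 nM, with a range of 2500 nM to 50000 nM.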

Compound 4, half-maximal inhibitory concentration: > 5000 nM
Compound 4 ended at the assay's limit; the forecaster's own chance of this, stated with the estimate: 85%; the middle value lies beyond the limit too.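

No new step can be read, because compound 1 and compound 4 both sit at the assay's limit: the limit of > 5000 nM in this assay, at which 4 of the 4 values shown sit.

Still open, on these data alone, is whether any change to the shared core gives a measurable value, and what 2H-tetrazol-5-yl in place of methoxycarbonyl does away from the limit.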